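Swapping the Outer Aryl Group in a Bile Acid Receptor Series

The source may report more compounds than this note shows. Statements on the series, on what has been measured and on what is new or still open speak of the compounds shown alone.

Of the compounds shown here, three built on one shared core have been tested in an assay on isolated protein with Bile acid receptor (Homo sapiens) as the target; a lower number here means that less compound is needed, a higher number that more compound is needed for the effect. Compound 1 `COC(=O)/C=C/c1cccc(N(Cc2ccc(/C=C/c3c(Cl)cccc3Cl)cc2)C(=O)C(C)C)c1` gives 195 nM. Compound 2 `COC(=O)/C=C/c1cccc(N(Cc2ccc(-c3ccc(SC)cc3)cc2)C(=O)C(C)C)c1` gives 51 nM, and compound 3 `COC(=O)/C=C/c1cccc(N(Cc2ccc(-c3ccc(OC(F)(F)F)cc3)cc2)C(=O)C(C)C)c1` gives 219 nM. Among the measured compounds shown here, compound 3 thus carries the highest of the three numbers, but its gap to compound 1 lies within the scatter, so the two cannot be ordered; only the step of a 4.3-fold higher number from compound 2 to compound 3 (0.63 log units; beyond the scatter) lies beyond the scatter.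

Compound 4 `COC(=O)/C=C/c1cccc(N(Cc2ccc(-c3cccc(OC)c3)cc2)C(=O)C(C)C)c1` differs from compound 3 in a single place: 3-methoxyphenyl in place of 4-(trifluoromethoxy)phenyl on an aromatic carbon. For the measured compounds named here, the one measured step that touches this part of the molecule is a 4.3-fold higher number from compound 2 to compound 3 (0.63 log units; beyond the scatter), which shows that changing the group on the outer ring can shift the number modestly. Going by the values given here, no measured compound carries a methoxy group, and none carries its substituent at the position named here, so the direction of the shift is not fixed by the data; a modest move either way, or none beyond the scatter, is plausible. Since compound 3 sits at the high end of the measured numbers, a slight move downward is taken as the more likely outcome. Compound 4 is expected to give 130 nM, with a range from 40 nM to 420 nM. This amounts to an expected step of a 1.7-fold lower number from compound 3 to compound 4 (0.23 log units; within the scatter).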

Compound 4, half-maximal effective concentration: 72 nM
Compound 4: middle estimate off by 1.8-fold (0.26 log units), on the high side; low and high end bracket the measured number.
By their numbers in this assay, from the lowest: compounds 2 and 4 (each within the scatter of the next); then compounds 1 and 3 (each within the scatter of the next).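

In this assay, among the compounds shown here, 3-methoxyphenyl in place of 4-(trifluoromethoxy)phenyl gives a 3.0-fold lower number from compound 3 to compound 4 (0.48 log units; beyond the scatter), the first evidence that a methoxy-bearing outer ring can lower the number from the high end of this small set. The same group also gives a 1.4-fold higher number from compound 2 to compound 4 (0.15 log units; within the scatter) against 4-(methylsulfanyl)phenyl, so these two different outer rings cannot be ordered, while a 2.7-fold lower number from compound 1 to compound 4 (0.43 log units; beyond the scatter) separates 3-methoxyphenyl from the 2-(2,6-dichlorophenyl)ethenyl group. These steps show that a low number at this place does not depend on the methylsulfanyl group alone, but no measurement shown here explains the shifts.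

The step to compound 4 changes both the substituent and where it sits on the outer ring, so the effect of each cannot be read separately; 4-methoxyphenyl and 3-(trifluoromethoxy)phenyl at this place would be needed to separate them. Also open is how this place responds to an outer ring carrying an amine or a carboxylic acid, since every outer substituent shown here is a chlorine, a methoxy, a trifluoromethoxy or a methylsulfanyl group.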